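The source may report more compounds than this note shows. Statements on the series, on what has been measured and on what is new or still open speak of the compounds shown alone.

Working notes on the series.

Compound 1 `CCc1nc2c(OCc3ccccc3)cccn2c1N` and compound 2 `CCCc1nc2c(OCc3ccccc3)cccn2c1N` share a core; in a functional assay on the whole organism with Rattus norvegicus as the target, at a dose of 40 mg/kg by the intraperitoneal route (on this read-out higher numbers stand for more inhibition at the one dose given (going by the name of the read-out) and lower numbers for less inhibition), compound 1 gives 83%, and compound 2 gives 31%. The step of a number 52 percentage points lower from compound 1 to compound 2 (beyond the scatter) goes with the change (methyl in place of hydrogen on a saturated chain carbon, two bonds along the chain from an aromatic carbon).

Compound 3 `CCNc1c(C)nc2c(OCc3ccccc3)cccn12` stands on a different core; the difference between the two cores is not broken down here. In this assay compound 3 gives 95%, the highest of the three numbers, with compound 1 nearest and compound 2 furthest, both beyond the scatter.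

Compound 4 `CCCNc1c(C)nc2c(OCc3ccccc3)cccn12` is not yet measured. It differs from compound 3 by methyl in place of hydrogen on a saturated chain carbon, two bonds along the chain from a nitrogen on an aromatic ring. This is the same kind of change as from compound 1 to compound 2, not the same: there the place is two bonds along the chain from an aromatic carbon, here it is two bonds along the chain from a nitrogen on an aromatic ring. Among the compounds with values here, with only one measured example of the change, the step from compound 3 to compound 4 in this assay is expected to be a drop of broadly the same kind, estimated as a number 40 percentage points lower from compound 3 to compound 4 (beyond the scatter), resting on compound 1 and compound 2 and their step of a number 52 percentage points lower from compound 1 to compound 2 (beyond the scatter). Compound 4 is therefore estimated at 55%, in the range 25% to 85%.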

Compound 4, a percentage reported as inhibition, in the whole organism at one dose (the size of the read-out at that dose, not a potency): 99%
Compound 4: the middle estimate sits 44 percentage points below what was measured; measured number above the stated range.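

In this assay the change from ethylamino to propylamino comes out as a number 4 percentage points higher from compound 3 to compound 4 (within the scatter), so on this core the added methyl shows no measurable effect at the one dose given. The change therefore does not carry over unchanged from the core of compound 1 to the core of compound 3: the same change on two cores in this assay, a number 52 percentage points lower (beyond the scatter) from compound 1 to compound 2 and a number 4 percentage points higher (within the scatter) from compound 3 to compound 4, 56 percentage points apart, beyond the scatter of two such steps This rests on a single pair on each core and does not show what separates the two results, since the place of the change also differs, two bonds along the chain from an aromatic carbon in one pair and two bonds along the chain from a nitrogen on an aromatic ring in the other.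

The compounds shown leave open how a longer chain such as butylamino, or a branched one such as isopropylamino, reads on the core of compound 3. Also open, from the compounds shown here alone, is how a butyl chain reads on the core of compound 2, which gives 31% with its propyl chain.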